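The source may hold more compounds than are shown below. What is called first, only, known or untested is meant among the compounds shown, and "the series" means these compounds.

Compound 1, `COc1ccc(F)cc1C(C)NC(=O)N(C)S(=O)(=O)c1ccc(C)cc1`: 11700 nM
Compound 2, `COc1ccc(F)cc1C(C)NC(=O)N(C)S(=O)(=O)c1ccccc1`: 10000 nM

In a functional assay on thoracic aorta (Rattus norvegicus, strain Wistar), with a stated time of 15 min (on this read-out lower numbers stand for an effect already at smaller amounts and higher numbers for an effect only at larger amounts of compound), compound 1 gives 11700 nM and compound 2 gives 10000 nM. Among the measured compounds shown here, on the bare numbers compound 2 stands lowest of the two, yet the only measured step, a 1.2-fold lower number from compound 1 to compound 2 (0.07 log units; within the scatter), lies within the scatter, so the two compounds cannot really be told apart. Compound 3, `COc1ccc(F)cc1C(C)NC(=O)N(C)S(=O)(=O)c1ccc(Cl)cc1`, has not yet been measured. It differs from compound 2 by chloro in place of hydrogen on an aromatic carbon. For the measured compounds named here, the one step that bears on this change is the one between compound 1 and compound 2, where a group at the very same place brought nothing beyond the scatter. A step of about that size is therefore expected, without a clear direction: a 1.1-fold lower number from compound 2 to compound 3 (0.05 log units; within the scatter). Compound 3 is expected to give about 9000 nM in this assay, within a range from 3000 nM to 27000 nM.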

Compound 3, half-maximal effective concentration: 12600 nM
Estimate against measurement, compound 3: 1.4-fold (0.15 log units) below, and the stated range covers the measured number.
By their numbers in this assay, from the lowest: compounds 2, 1 and 3 (each within the scatter of the next).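

In this assay chloro on the aromatic carbon para to a large group can now be set against both hydrogen and methyl at this same place: replacing hydrogen gives a 1.3-fold higher number from compound 2 to compound 3 (0.10 log units; within the scatter) and replacing methyl gives a 1.1-fold higher number from compound 1 to compound 3 (0.03 log units; within the scatter). Both steps lie within the scatter, so hydrogen, methyl and chloro at this place cannot be told apart on this read-out, and the earlier lack of a clear effect with methyl now extends to a second group, chloro. Nothing available offers an explanation for this flat result.

Still open, from the compounds shown here alone, is whether a group of another kind at this place, such as an amine, a carboxylic acid or a longer chain, would shift the number beyond the scatter. Also open, going by these compounds, is whether chloro on a different carbon of the same ring would do so.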